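The compounds below may be only part of what the source reports. "The series", "measured", "known", "first", "only" and "open" are said of these compounds alone.

Values in a functional assay (aorta) with Rattus norvegicus as the target; a higher number here means that more compound is needed for the effect, a lower number that less compound is needed:
- Compound 1 `CN(C)/C(=N\C#N)C1=CC(C)(C)Oc2ccc(C#N)cc21`: 5010 nM
- Compound 2 `CN(C)/C(=N\C#N)C1=CC(C)(C)Oc2ccc(Br)cc21`: > 31600 nM
- Compound 3 `CN(C)/C(=N\C#N)C1=CC(C)(C)Oc2ccc(Cl)cc21`: > 31600 nM

Compound 3 stands at > 31600 nM, which is a limit of the assay and not a number. Compound 4 `CN(C)/C(=N\C#N)C1=CC(C)(C)Oc2ccccc21` differs from it by hydrogen in place of chloro on an aromatic carbon, with hydrogen in place of chloro on an aromatic carbon.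

The closest evidence comes from replacing cyano on that same carbon. Both changes raised the number beyond the scatter: an at least 6.3-fold higher number from compound 1 to compound 3 (0.79 log units; beyond the scatter) and an at least 6.3-fold higher number from compound 1 to compound 2 (0.79 log units; beyond the scatter). The step that the two limits leave unreadable from compound 2 to compound 3 tells nothing further. Compound 4 also lacks the cyano, so no readable step from the chloro compound is expected, and a limit is the likeliest result.

The expected change is a step that the limit leaves unreadable from compound 3 to compound 4. The estimate for compound 4 is 35000 nM, within an expected range of 10000 nM to 100000 nM.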

Compound 4, half-maximal effective concentration: > 31600 nM
Compound 4 gave a limit, no number; the forecaster's own chance of this, stated with the estimate: 75%; the middle value is on the limit's open side.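

In this assay the change to plain hydrogen gives an at least 6.3-fold higher number from compound 1 to compound 4 (0.79 log units; beyond the scatter) so the loss seen with bromo and chloro on this carbon also appears with no substituent there at all. Of the groups shown on this carbon, only the nitrile of compound 1 gives a number. The steps to compound 4 from compound 2 and compound 3 cannot be read, since these values are limits and not numbers: the limit of > 31600 nM in this assay, at which 3 of the 4 values shown sit.

Bromo, chloro and hydrogen therefore stay unranked. On these data alone, whether a methoxy group, an amine or a carboxylic acid on this carbon would give a number remains open.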